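This account rests on a few compounds, and the source may have more. Where it says the series, first, only, none or still open, it means among the compounds named here.

In a functional assay on MCF7 cells (Homo sapiens) for cytotoxicity, read by MTT assay, with a stated time of 2 days, tested at 1 uM (on this read-out higher numbers stand for a weaker effect at the one concentration tested and lower numbers for a stronger effect), compound 3 `COc1ccc(-c2cc3cc(-c4ccccc4)cc(C(C)=O)c3[nH]2)cc1` gives 78.1%. Compound 1 `CC(=O)c1cc(-c2ccc(F)cc2)cc2cc(-c3ccccc3)[nH]c12` gives 82.7%, a gap that lies within the usual scatter, so these two compounds cannot be told apart on this measure. Compound 2 `CC(=O)c1cc(-c2ccc(F)cc2)cc2cc(-c3ccc(F)cc3)[nH]c12` gives 93.2%, and its gap to compound 3 is beyond the scatter, so compound 2 shows the weaker effect of the pair.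

Compound 4 `COc1ccc(-c2cc3cc(-c4ccc(F)cc4)cc(C(C)=O)c3[nH]2)cc1` differs from compound 3 in a single place: fluoro in place of hydrogen on an aromatic carbon. One measured step carries exactly this change on the same ring: a number 10.5 percentage points higher from compound 1 to compound 2 (beyond the scatter). Compounds 1 and 2 differ from compounds 3 and 4 only elsewhere in the molecule. That step was modest, yet larger than the scatter, and pointed toward a weaker effect.

Among the measured compounds shown here, with only that one step to go on, a shift of about the same size and in the same direction is the natural expectation, while the range must stay wide enough to allow for a step that vanishes into the scatter. The step from compound 3 to compound 4 is therefore expected to be a number 8.9 percentage points higher from compound 3 to compound 4 (within the scatter). The estimate for compound 4 is 87%, with a likely range from 76% to 97%.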

Compound 4, a percentage reported as activity, at one concentration (the size of the read-out at that concentration, not a potency): 96.4%
Compound 4: the middle estimate sits 9.4 percentage points below what was measured; the range from low to high includes it.
By their numbers in this assay, from the lowest: compounds 3 and 1 (each within the scatter of the next); then compounds 2 and 4 (each within the scatter of the next).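

The change from phenyl to 4-fluorophenyl now also moves the number up on a second core in this assay (a number 18.3 percentage points higher from compound 3 to compound 4 (beyond the scatter)), so fluoro goes with a weaker effect in both pairs that carry this change, and the two steps agree in size: the same change on two cores in this assay, a number 10.5 percentage points higher (beyond the scatter) from compound 1 to compound 2 and a number 18.3 percentage points higher (beyond the scatter) from compound 3 to compound 4, 7.8 percentage points apart, within the scatter of two such steps

A methoxy group in place of fluoro on an aromatic carbon makes no difference that can be read (a number 3.2 percentage points higher from compound 2 to compound 4 (within the scatter)), so on this measure the two groups cannot be told apart at that place. Methoxy in place of hydrogen at that same place does give a step larger than the scatter (a number 13.7 percentage points higher from compound 1 to compound 4 (beyond the scatter)), so there a substituent of either kind goes with a weaker effect than plain hydrogen, although this rests on a single pair for each group.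

Going by these compounds, whether a chloro group, an amine or a carboxylic acid at these places would follow the same trend stays open. On these data alone, each number comes from a single concentration, so how these steps would translate into differences in potency also stays open.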